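Replacing Thiophene with Methoxyphenyl on a Fused Core

The source may hold more compounds than are shown below. What is called first, only, known or untested is meant among the compounds shown, and "the series" means these compounds.

Compound 1, `C=C(Br)C(=O)Nc1cccc(-c2cn3nc(Cc4ccc(Cl)cc4)sc3n2)c1`, gives 1100 nM in a functional assay on FM3A cells (Mus musculus) for inhibition, read by cell counting, with a stated time of 2 days; a lower number here means a stronger inhibitor, a higher number a weaker inhibitor. Compound 2, `C=C(Br)C(=O)Nc1cccc(-c2cn3nc(-c4cccs4)sc3n2)c1`, gives 370 nM in this assay.

Compound 2 stands lowest of the two numbers; its nearest neighbour is compound 1, with a 3.0-fold lower number from compound 1 to compound 2 (0.47 log units; beyond the scatter). Compound 3 is `C=C(Br)C(=O)Nc1cccc(-c2cn3nc(-c4ccc(OC)cc4)sc3n2)c1`, differing from compound 2 by 4-methoxyphenyl in place of thiophen-2-yl on an aromatic carbon. Going by the values given here, the only measured step bearing on this, the one from compound 1 to compound 2, also exchanged the group at this position and gave a modest change. For compound 3 a modest shift in either direction is therefore expected, a 1.6-fold higher number from compound 2 to compound 3 (0.21 log units; within the scatter). Compound 3 is estimated at 600 nM, within 200 nM to 2000 nM.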

Compound 3, half-maximal inhibitory concentration: 890 nM
Estimate against measurement, compound 3: 1.5-fold (0.17 log units) below; low and high end bracket the measured number.
By their numbers in this assay, from the lowest: compound 2; then compounds 3 and 1 (each within the scatter of the next).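

In this assay, a second exchange at this position, 4-methoxyphenyl in place of thiophen-2-yl, gives a 2.4-fold higher number from compound 2 to compound 3 (0.38 log units; beyond the scatter) and leaves thiophen-2-yl with the lowest number of the three groups. The exchange of 4-chlorobenzyl for 4-methoxyphenyl gives a 1.2-fold lower number from compound 1 to compound 3 (0.09 log units; within the scatter) and so does not separate these two groups, although one is attached through a carbon chain link and the other directly. Nothing available explains these differences.

The compounds shown leave open how an amine, a carboxylic acid or a longer chain at this position would read in this assay.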